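A Bromo for Chloro Swap at the Assay Limit

A few compounds are considered here, and "the series" means these few. Any claim that something is new, unique, unknown or untested is made for them only; others in the source may bear on it.

In a functional assay on HeLa cells (Homo sapiens) for inhibition, read by MTT assay, with a stated time of 48 h (a higher number here means a weaker inhibitor, a lower number a stronger inhibitor), compound 3 `N#Cc1ccc2[nH]cc(C(c3ccc(Cl)cc3)c3c[nH]c4ccc(C#N)cc34)c2c1` gives > 100000 nM, which is a limit and not a number. It therefore stands at the limit of > 100000 nM in this assay, at which 1 of the 3 values shown sits. Compound 4 `N#Cc1ccc2[nH]cc(C(c3ccc(Br)cc3)c3c[nH]c4ccc(C#N)cc34)c2c1` changes one group: bromo in place of chloro on an aromatic carbon, so that 4-chlorophenyl becomes 4-bromophenyl. Going by the values given here, no measured step covers this swap. The nearest evidence comes from compound 1 `Oc1cccc(C(c2c[nH]c3ccc(Br)cc23)c2c[nH]c3ccc(Br)cc23)c1`, which gives 3900 nM, and compound 2 `CCCC(c1c[nH]c2ccc(Br)cc12)c1c[nH]c2ccc(Br)cc12`, which gives 3900 nM. Even propyl in place of 3-hydroxyphenyl, a change elsewhere in the molecule, produced no change at the digits printed from compound 1 to compound 2 (within the scatter). In this assay no step beyond the scatter is therefore expected for the smaller swap. The estimated step is a number no higher from compound 3 to compound 4 (the limit leaves the size open). Compound 4 is expected near 100000 nM, with an estimated range of 30000 nM to 300000 nM.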

Compound 4, half-maximal inhibitory concentration: > 100000 nM
Compound 4 was reported as a limit; the forecaster's own chance of this, stated with the estimate: 65%; the middle value sits exactly at the limit.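

Going by these compounds alone, compound 3 and compound 4 are both reported only as limits, so no step between them can be read: the limit of > 100000 nM in this assay, at which 2 of the 4 values shown sit. The compounds shown leave open whether bromo in place of chloro changes the inhibition in these cells at all.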